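One Dichloro Swap Carried Over to a Second Core

A few compounds are considered here, and "the series" means these few. Any claim that something is new, unique, unknown or untested is made for them only; others in the source may bear on it.

compound 1 `O=C(/C=C/c1ccccc1)Nc1cc2c(Nc3ccc(Cl)c(Cl)c3)ncnc2s1`: 7600 nM
compound 2 `O=C(/C=C/c1ccccc1)Nc1cc2ncnc(Nc3cc(Cl)cc(Cl)c3)c2s1`: 12500 nM
compound 3 `O=C(/C=C/c1ccccc1)Nc1cc2c(Nc3cc(Cl)cc(Cl)c3)ncnc2s1`: 40 nM

In a functional assay on A549 cells (Homo sapiens) for antiproliferative activity, read by MTT assay, with a stated time of 48 h (a lower number here means a stronger inhibitor, a higher number a weaker inhibitor), compound 3 gives 40 nM, the lowest of the three values and the only one standing clearly apart. The change 3,4-dichlorophenyl in place of 3,5-dichlorophenyl on a nitrogen on an aromatic ring made a 190-fold higher number from compound 3 to compound 1 (2.28 log units; beyond the scatter). Compound 1 gives 7600 nM and compound 2 gives 12500 nM, two numbers lying within the scatter of each other. The difference between the cores of compound 2 and compound 3 is not broken down here.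

Compound 4 `O=C(/C=C/c1ccccc1)Nc1cc2ncnc(Nc3ccc(Cl)c(Cl)c3)c2s1` is not yet measured. It carries the same change, (3,4-dichlorophenyl in place of 3,5-dichlorophenyl on a nitrogen on an aromatic ring), on the core of compound 2. Going by the values given here, the step of a 2.4-fold higher number from compound 2 to compound 4 (0.38 log units; beyond the scatter) is expected to be a rise, but a smaller one than the earlier step, because the only precedent is a 190-fold higher number from compound 3 to compound 1 (2.28 log units; beyond the scatter) on a different core and compound 2 already gives 12500 nM. Compound 4 is therefore estimated at 30000 nM, with 8000 nM to 150000 nM as the likely range.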

Compound 4, half-maximal inhibitory concentration: 19500 nM
For compound 4 the middle estimate is 1.5-fold (0.19 log units) above the measured one; the range from low to high includes it.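

In this assay, the same swap on the second core gave a 1.6-fold higher number from compound 2 to compound 4 (0.19 log units; within the scatter), so nothing of the large rise seen on the first core can be read there. These two cores alone do not show why the step differs, or how the change would behave on any further core. What they do show is that, in this series, the size of the step did not carry from one core to the other: the same change on two cores in this assay, a 190-fold higher number (2.28 log units; beyond the scatter) from compound 3 to compound 1 and a 1.6-fold higher number (0.19 log units; within the scatter) from compound 2 to compound 4, 120-fold (2.09 log units) apart, beyond the scatter of two such steps

The compounds shown leave open how a single chlorine, a methoxy group or a trifluoromethyl group on the aniline phenyl ring would fare on either core. They also leave open whether an amine on the phenyl ring of the amide side chain would change the picture.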